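The source may report more compounds than this note shows. Statements on the series, on what has been measured and on what is new or still open speak of the compounds shown alone.

Measured compounds and their values:
compound 1, `CC(C)(C)OC(=O)N1CCC(CCOC(=O)N2CCc3cc(S(C)(=O)=O)ccc32)CC1`, 3.1
compound 2, `CC(CC1CCN(C(=O)OC(C)(C)C)CC1)OC(=O)N1CCc2cc(S(C)(=O)=O)ccc21`, 3.4
compound 3, `CC(C)(C)OC(=O)N1CCC(C(O)COC(=O)N2CCc3cc(S(C)(=O)=O)ccc32)CC1`, 2.1

All three were measured in a physicochemical assay for lipophilicity, read by HPLC, measured as octanol-water partition, at pH 7.4; a higher number here means a more lipophilic compound, a lower number a more polar compound. Compound 1 stands second highest of the three numbers. Its nearest neighbour is compound 2, a number 0.30 log units higher from compound 1 to compound 2 (within the scatter), a gap within the scatter of the method. Its furthest neighbour is compound 3, a number 1.00 log units lower from compound 1 to compound 3 (beyond the scatter), a gap beyond the scatter.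

Compound 4, `Cc1c(S(C)(=O)=O)ccc2c1CCN2C(=O)OCCC1CCN(C(=O)OC(C)(C)C)CC1`, has not yet been measured. It differs from compound 1 in one place: methyl in place of hydrogen on an aromatic carbon. Within the data shown here, of the two measured steps, the one from compound 1 to compound 2 bears on this change, as it also puts a methyl in place of a hydrogen, though on a saturated chain carbon rather than an aromatic one, and it gave a number 0.30 log units higher from compound 1 to compound 2 (within the scatter). The step to compound 3 introduces a hydroxy group and does not inform this change. Because a number 0.30 log units higher from compound 1 to compound 2 (within the scatter) was small, the expectation for compound 4 is a step upward of about a number 0.40 log units higher from compound 1 to compound 4 (beyond the scatter), which may or may not clear the scatter. The estimated value for compound 4 is 3.5, with a likely range from 3.1 to 3.9.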

Compound 4, distribution coefficient: 3.4
Estimate against measurement, compound 4: 0.10 log units above; the measured number falls inside the stated range.
By their numbers in this assay, from the lowest: compound 3; then compounds 1, 2 and 4 (each within the scatter of the next).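

In this assay, putting a methyl in place of hydrogen on this aromatic carbon, ortho to a methylsulfonyl group, gives a number 0.30 log units higher from compound 1 to compound 4 (within the scatter), so this reading cannot be told apart from that of compound 1. Among these compounds, until now, methyl had been seen only on a saturated chain carbon, with a number 0.30 log units higher from compound 1 to compound 2 (within the scatter); the aromatic carbon now gives a second place where a methyl step stays within the scatter, although two places are too few to make a general rule. No measured evidence here explains why the aromatic methyl step is this size.

The compounds shown leave open whether a different group on this same aromatic carbon, such as an amine, a carboxylic acid or a longer chain, would give a step beyond the scatter, as the hydroxy on the saturated chain carbon did with a number 1.00 log units lower from compound 1 to compound 3 (beyond the scatter). They also leave open whether a methyl on another aromatic carbon of the shared core would give a step of similar size in this assay.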